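Swapping a diethylamino urea cap for a fused aromatic ring

A few compounds are considered here, and "the series" means these few. Any claim that something is new, unique, unknown or untested is made for them only; others in the source may bear on it.

Compound 1 `CCN(CC)C(=O)NCCCC(C)Nc1cc(OC)cc2cccnc12` carries a urea on a shared core. In a functional assay on SW-620 cells (Homo sapiens), read by MTT assay, with a stated time of 72 h (a higher number here means a weaker inhibitor, a lower number a stronger inhibitor), compound 1 reaches only the limit of the assay, > 100000 nM, so its true number is not known. Compound 2 `COc1cc(NC(C)CCCNC(=O)NC2CCCC2)c2ncccc2c1` differs in one place and gives 19000 nM in this assay. That change, an at least 5.2-fold lower number from compound 1 to compound 2 (0.72 log units; beyond the scatter), shows that swapping the diethylamino group on the carbonyl carbon can strengthen inhibition. As far as these compounds go, the size of that step stays open because the limit of > 100000 nM in this assay, at which 1 of the 2 values shown sits, hides where compound 1 truly sits. Compound 3 `COc1cc(NC(C)CCCNC(=O)n2nnc3ccccc32)c2ncccc2c1` makes a different swap at the same place: a group of 9 heavy atoms (6 carbon, 3 nitrogen; one five-membered aromatic ring with 3 hetero atoms, one six-membered aromatic ring of carbon only) in place of a group of 5 heavy atoms (4 carbon, 1 nitrogen; no ring), on a carbonyl carbon. For the measured compounds named here, only the step from compound 1 to compound 2 bears on this, and it points toward a lower number, but the entering group here is aromatic rather than a saturated ring, so a smaller and uncertain step is expected. Compound 3 is therefore expected to give 30000 nM, with a range from 5000 nM to 150000 nM. This means an expected step of an at least 3.3-fold lower number from compound 1 to compound 3 (0.52 log units; beyond the scatter).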

Compound 3, half-maximal inhibitory concentration: > 100000 nM
Compound 3 ended at the assay's limit; the forecaster's own chance of this, stated with the estimate: 30%; at least 3.3-fold (0.52 log units) between middle value and limit.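

In this assay, replacing diethylamino does not by itself lower the number: the group that enters on the carbonyl carbon decides the outcome. Putting the fused aromatic group in place of the cyclopentylamino group gives an at least 5.2-fold higher number from compound 2 to compound 3 (0.72 log units; beyond the scatter). The step from compound 1 to compound 3 cannot be read, because both compounds sit at the same limit: the limit of > 100000 nM in this assay, at which 2 of the 3 values shown sit.

As far as these compounds go, whether compound 3 is stronger or weaker than compound 1 therefore stays open, since neither true number is known. Also open, from the compounds shown here alone, is whether a cyclohexyl or cyclopropyl ring on the carbonyl carbon would match or improve on compound 2, and whether a single phenyl ring there would behave like the saturated ring or like the fused aromatic group.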